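From Ethyl to Vinyl on Compound 2

This account rests on a few compounds, and the source may have more. Where it says the series, first, only, none or still open, it means among the compounds named here.

Of the compounds shown here, two have numbers so far. In a functional assay on P388 cells (Mus musculus) for cytotoxicity (a lower number here means a stronger inhibitor, a higher number a weaker inhibitor), compound 1 (`COc1ccc(C[C@H]2C(=O)N[C@@H](C)C(=O)N(C)[C@H]3Cc4ccc(cc4)Oc4cc(ccc4OC)C[C@@H](C(=O)N[C@H](C)C(=O)N[C@@H](CC=O)C(=O)N2C)N(C)C3=O)cc1`) reads 33.9 nM and compound 2 (`CCCN1C(=O)[C@@H](C)NC(=O)[C@@H]2Cc3ccc(OC)c(c3)Oc3ccc(cc3)C[C@@H](C(=O)N2C)N(C)C(=O)[C@H](C)NC(=O)[C@H](Cc2ccc(OC)cc2)N(C)C(=O)[C@@H]1C`) reads lower (3.98 nM). Compound 2 therefore holds the lower number of the pair, and the gap between them lies beyond the usual scatter of repeated measurements. That makes compound 2 the stronger inhibitor of these two and a natural reference for the next compound.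

Compound 3 (`C=CCN1C(=O)[C@@H](C)NC(=O)[C@@H]2Cc3ccc(OC)c(c3)Oc3ccc(cc3)C[C@@H](C(=O)N2C)N(C)C(=O)[C@H](C)NC(=O)[C@H](Cc2ccc(OC)cc2)N(C)C(=O)[C@@H]1C`) differs from compound 2 in one place: vinyl in place of ethyl on a saturated chain carbon bound to an amide-type nitrogen in a ring. The same difference, cut one bond further out, reads propyl to allyl. The swap adds a double bond outside aromatic rings and brings no charge.

Among the compounds with values here, no measured pair shows what this swap does, so compound 2 at 3.98 nM is the only starting point. The expected change (a 1.1-fold higher number from compound 2 to compound 3 (0.05 log units; within the scatter)) stays within the scatter, with no clear direction. In this assay compound 3 is estimated at 4.5 nM with a range (1.5 nM to 14 nM).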

Compound 3, half-maximal inhibitory concentration: 18.6 nM
Estimate against measurement, compound 3: 4.1-fold (0.62 log units) below; the measured number lies above the stated range.
By their numbers in this assay, from the lowest: compound 2; then compounds 3 and 1 (each within the scatter of the next).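

In this assay, the position on a saturated chain carbon bound to an amide-type nitrogen in a ring turns out to respond to a very small change: vinyl in place of ethyl gives a 4.7-fold higher number from compound 2 to compound 3 (0.67 log units; beyond the scatter), which makes compound 3 the weaker inhibitor of this pair. Ethyl and vinyl have the same count of heavy atoms, neither has a hydrogen-bond donor or acceptor, and neither carries a charge, so the one counted difference is the double bond outside aromatic rings. The earlier compounds offered no step at this position, and this pair gives the first sign that it is not indifferent to what sits there, although no supporting measurement exists that would explain the loss.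

This is a single change at a single position, so it leaves open whether the double bond itself matters or whether other replacements for ethyl would also raise the number. A longer chain such as butyl, a triple bond in place of the double bond, or an amine or a carboxylic acid on the chain could each help to settle that question.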